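Compound 4: swapping the amine link for an ether

This account rests on a few compounds, and the source may have more. Where it says the series, first, only, none or still open, it means among the compounds named here.

Measured so far in a physicochemical assay for lipophilicity; on this read-out lower numbers stand for lower lipophilicity and higher numbers for higher lipophilicity:
Compound 1 `N[C@H]1CC[C@H](Nc2ccc3ncc(-c4cnc(Nc5ncccc5F)nc4)n3n2)CC1` gives 0.2
Compound 2 `CN1CC[C@H](Nc2ccc3ncc(-c4cnc(Nc5ncccc5F)nc4)n3n2)C1` gives 1.5
Compound 3 `Fc1cccnc1Nc1ncc(-c2cnc3ccc(NCCN4CCCC4)nn23)cn1` gives 1.5

Compound 3, at 1.5 on this scale, stands level with compound 2, and the two share the top of this small set. Compound 1 lies clearly lower. The next structure is compound 4 `CN1CC[C@H](Oc2ccc3ncc(-c4cnc(Nc5ncccc5F)nc4)n3n2)C1`, and it differs from compound 3 in one place ((1-methylpyrrolidin-3-yl)oxy in place of (2-(pyrrolidin-1-yl)ethyl)amino on an aromatic carbon). In words, (1-methylpyrrolidin-3-yl)oxy takes the place of (2-(pyrrolidin-1-yl)ethyl)amino on an aromatic carbon.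

The closest evidence is no change at the digits printed from compound 2 to compound 3 (within the scatter), a swap between 1-methylpyrrolidin-3-yl and 2-(pyrrolidin-1-yl)ethyl on a nitrogen. That swap moved nothing beyond the scatter. The two large steps, a number 1.30 log units higher from compound 1 to compound 2 (beyond the scatter) and a number 1.30 log units higher from compound 1 to compound 3 (beyond the scatter), both start from 4-aminocyclohexyl, a group that plays no part in this change, so they say little here. For the measured compounds named here, no measured pair shows oxygen replacing nitrogen as the link, and that gap keeps the range wide. A small rise is expected, not clearly beyond the scatter, and the expected step is a number 0.30 log units higher from compound 3 to compound 4 (within the scatter) in this estimate. For this assay compound 4 is estimated at 1.8 (range 1.3 to 2.4).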

Compound 4, distribution coefficient: 1.5
Beside the measured number, compound 4's estimate is 0.30 log units above it; low and high end bracket the measured number.
By their numbers in this assay, from the lowest: compound 1; then compounds 2, 3 and 4 (each within the scatter of the next).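

The pair that changes only the link atom, (1-methylpyrrolidin-3-yl)oxy in place of (1-methylpyrrolidin-3-yl)amino on an aromatic carbon, gives no change at the digits printed from compound 2 to compound 4 (within the scatter) in this assay, so at this position oxygen can take over from nitrogen as the link without a shift beyond the scatter. The larger swap gives no change at the digits printed from compound 3 to compound 4 (within the scatter) even though the link and the side chain both change and the group goes from 1 hydrogen-bond donor to 0, so this read-out does not separate these two amine side chains on either link. The oxygen-linked compound also gives a number 1.30 log units higher from compound 1 to compound 4 (beyond the scatter) when it replaces the (4-aminocyclohexyl)amino group, but that step changes the link and the side chain together and cannot be assigned to either one alone.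

Nothing measured here explains why the read-out stays level across these changes.
On these data alone, it also remains open whether the same level would hold with a sulfur atom or a methylene group as the link, or with an oxygen link carrying the 4-aminocyclohexyl group.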